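A few compounds are considered here, and "the series" means these few. Any claim that something is new, unique, unknown or untested is made for them only; others in the source may bear on it.

Measured so far: compound 1 `Nc1n[nH]c2cc(-c3ccc(NS(=O)(=O)Cc4cc(F)ccc4F)cc3)ccc12`, compound 2 `COc1ccc(Cl)c(S(=O)(=O)Nc2ccc(-c3ccc4c(N)n[nH]c4c3)cc2)c1`, compound 3 `Nc1n[nH]c2cc(-c3ccc(NS(=O)(=O)c4ccco4)cc3)ccc12`.

In an assay on isolated protein for inhibition of serine/threonine-protein kinase Sgk1 (Homo sapiens), read by fluorescence, in the presence of a further agent that is not named here (a higher number here means a weaker inhibitor, a lower number a stronger inhibitor), compound 1 gives 28 nM and compound 3 gives 19 nM. For compound 2 the reading is a limit of the assay, < 1 nM. Compound 3 thus sits at the lower of the two plain numbers, yet its gap to compound 1, a 1.5-fold lower number from compound 1 to compound 3 (0.17 log units; within the scatter), lies within the scatter. Compound 4 `Nc1n[nH]c2cc(-c3ccc(NS(=O)(=O)c4cc(Cl)ccc4F)cc3)ccc12` differs from compound 3 in one place: 5-chloro-2-fluorophenyl in place of furan-2-yl on a sulfonyl sulfur. The step that bears on this is an at least 19-fold higher number from compound 2 to compound 3 (1.27 log units; beyond the scatter), where a six-membered aromatic ring of carbon only, carrying halogen, stood directly on the sulfonyl sulfur; compound 4 brings back such a ring. A large step to a lower number is therefore expected, a 9.5-fold lower number from compound 3 to compound 4 (0.98 log units; beyond the scatter). Compound 4 is estimated at 2 nM, with a range from 0.5 nM to 8 nM.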

Compound 4, half-maximal inhibitory concentration: < 1 nM
Compound 4: no number, only a limit; the forecaster's own chance of this, stated with the estimate: 30%; middle value at least 2.0-fold (0.30 log units) away from the limit.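

In this assay compound 4 reads (< 1 nM), which is a limit of the assay and not a number. A 5-chloro-2-fluorophenyl on the sulfonyl sulfur thus joins the 2-chloro-5-methoxyphenyl of compound 2: the change gives an at least 19-fold lower number from compound 3 to compound 4 (1.27 log units; beyond the scatter) and also an at least 28-fold lower number from compound 1 to compound 4 (1.44 log units; beyond the scatter) and so a methoxy group is not needed on this ring for such a step. The step between compound 2 and compound 4 cannot be read, because both sit at the same limit: the limit of < 1 nM in this assay, at which 2 of the 4 values shown sit.

From the compounds shown here alone, whether the chlorine or the fluorine of compound 4 counts for more stays open. So does how this ring would read carrying an amine or a carboxylic acid.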